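The source may hold more compounds than are shown below. What is called first, only, known or untested is meant among the compounds shown, and "the series" means these compounds.

Compound 2 `Cc1c(OC[C@@H](C)COc2ccc(C(=O)O)cc2Cl)ccc(C(=O)CC(C)(C)C)c1O` gives 477 nM in an assay for positive allosteric modulation of metabotropic glutamate receptor 2 (Rattus norvegicus); on this read-out higher numbers stand for an effect only at larger amounts of compound and lower numbers for an effect already at smaller amounts. For the measured compounds named here, its only measured neighbour, compound 1 `Cc1cc(C(=O)O)ccc1OC[C@H](C)COc1ccc(C(=O)CC(C)(C)C)c(O)c1C`, gives 446 nM in this assay, and the step of a 1.1-fold higher number from compound 1 to compound 2 (0.03 log units; within the scatter) shows that the two numbers lie within the scatter of one another, so compound 2 stands level with the only other compound recorded. The move to compound 3 `Cc1c(OC[C@@H](C)COc2ccc3c(c2)C(=O)NC3)ccc(C(=O)CC(C)(C)C)c1O` is a change of another kind: a group of 10 heavy atoms (8 carbon, 1 nitrogen, 1 oxygen; one five-membered non-aromatic ring with 1 hetero atom, one six-membered aromatic ring of carbon only) in place of a group of 10 heavy atoms (7 carbon, 2 oxygen, 1 chlorine; one six-membered aromatic ring of carbon only), on an oxygen on a saturated carbon. Going by the values given here, the single measured step, a 1.1-fold higher number from compound 1 to compound 2 (0.03 log units; within the scatter), swaps one small substituent for another while the carboxy group stays in place on both compounds; it therefore says nothing about exchanging the whole 4-carboxy-2-chlorophenyl group for the entering group in compound 3. Among the compounds with values here, no measured step bears directly on this change. With the one shown step within the scatter, there is no ground for expecting a large shift in a fixed direction, but the departure of the carboxy group shared by both measured compounds widens the uncertainty, and the estimate leans toward a somewhat higher number. Compound 3 is expected to give 1000 nM in this assay, within a range from 300 nM to 4000 nM. That estimate corresponds to an expected step of a 2.1-fold higher number from compound 2 to compound 3 (0.32 log units; beyond the scatter).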

Compound 3, half-maximal effective concentration: > 10000 nM
Compound 3: no number, only a limit; the forecaster's own chance of this, stated with the estimate: 10%; middle value at least 10-fold (1.00 log units) from the limit.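

In this assay, compound 3 carries no number, only a limit of the assay: the limit of > 10000 nM in this assay, at which 1 of the 3 values shown sits.

Even so, the exchange on the oxygen on a saturated carbon is a large one, with an at least 20-fold higher number from compound 2 to compound 3 (1.32 log units; beyond the scatter) and, for the group in compound 1, an at least 22-fold higher number from compound 1 to compound 3 (1.35 log units; beyond the scatter), although the leaving and entering groups have the same listed counts of heavy atoms, hydrogen-bond donors and hydrogen-bond acceptors. The earlier step, a 1.1-fold higher number from compound 1 to compound 2 (0.03 log units; within the scatter), showed only that chloro in place of methyl on the carboxy-bearing ring left the two numbers level, whereas this result shows that replacing the whole group at this position can move the read-out far beyond the scatter, so those matching counts do not keep the read-out level.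

The compounds shown do not separate the loss of the carboxy group from the arrival of the five-membered non-aromatic ring, since both occur in the same step. As far as these compounds go, it remains open whether a tetrazole or a sulfonamide in place of the carboxy group would keep the read-out near that of compound 2, and how far above the limit compound 3 lies.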